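From 4-chlorophenyl to phenyl on a shared core

The source may hold more compounds than are shown below. What is called first, only, known or untested is meant among the compounds shown, and "the series" means these compounds.

Values in a physicochemical assay, read by spectrophotometry, with a stated time of 6 min (on this read-out higher numbers stand for weaker inhibition and lower numbers for stronger inhibition), are as follows.
Compound 1 `O=C(CCc1nc2ccccc2c(=O)[nH]1)N/N=C/c1ccc(O)c(O)c1` gives 40000000 nM
Compound 2 `O=C(CCc1nc2ccccc2c(=O)[nH]1)N/N=C/c1ccc(O)cc1` gives 105000000 nM
Compound 3 `O=C(CCc1nc2ccccc2c(=O)[nH]1)N/N=C/c1ccc(Cl)cc1` gives 185000000 nM

Compound 3 cannot be told apart from its nearest neighbour, with a 1.8-fold higher number from compound 2 to compound 3 (0.25 log units; within the scatter), while its other gap is wider, with a 4.6-fold higher number from compound 1 to compound 3 (0.67 log units; beyond the scatter). The next compound, compound 4 `O=C(CCc1nc2ccccc2c(=O)[nH]1)N/N=C/c1ccccc1`, has not yet been measured. It differs by hydrogen in place of chloro on an aromatic carbon, para to a large group.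

Among the compounds with values here, two measured steps bear on this change. Exchanging the group at that carbon gave a 1.8-fold higher number from compound 2 to compound 3 (0.25 log units; within the scatter), so that exchange did not move the number beyond the scatter. Hydrogen replacing hydroxy on the same ring gave a 2.6-fold higher number from compound 1 to compound 2 (0.42 log units; beyond the scatter), which is only a modest step. Within the data shown here, no measured compound has a bare phenyl, so the evidence is indirect. In this assay no change beyond the scatter is therefore expected, and the estimated step is a 1.2-fold lower number from compound 3 to compound 4 (0.09 log units; within the scatter). For compound 4 the estimate is 150000000 nM, with an expected range of 70000000 nM to 320000000 nM.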

Compound 4, half-maximal inhibitory concentration: 265000000 nM
For compound 4 the middle estimate is 1.8-fold (0.25 log units) below the measured one; low and high end bracket the measured number.
By their numbers in this assay, from the lowest: compound 1; then compounds 2, 3 and 4 (each within the scatter of the next, the first and the last beyond it).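

In this assay taking away the chloro does not move the number beyond the scatter (a 1.4-fold higher number from compound 3 to compound 4 (0.16 log units; within the scatter)), so at this carbon, para to a large group, chloro and hydrogen cannot be told apart. The bare phenyl also gives the ring a direct reference: hydrogen in place of the hydroxy of compound 2 is a modest step beyond the scatter (a 2.5-fold higher number from compound 2 to compound 4 (0.40 log units; beyond the scatter)), although chloro in that place stayed within it, so the three groups fall into no clean order. With both hydroxy groups gone, the step is wider but still modest (a 6.6-fold higher number from compound 1 to compound 4 (0.82 log units; beyond the scatter)).

Nothing given here explains these steps. Going by these compounds, whether an amine or a carboxylic acid at that carbon would stand apart from hydrogen and chloro remains open.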